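The compounds below may be only part of what the source reports. "The series", "measured", "known", "first", "only" and "open" are said of these compounds alone.

Measured compounds in a functional assay for activation of retinoic acid receptor beta (Homo sapiens); a lower number here means a smaller maximal response, a higher number a larger maximal response:

compound 1 `CC1(C)CCC(C)(C)c2cc(C(=O)c3ccc(/C=C/C(=O)O)cc3)ccc21`: 78%
compound 2 `CC1(C)CCC(C)(C)c2cc(C(O)c3cccc(/C=C/C(=O)O)c3)ccc21`: 0%
compound 3 `Cc1cc(C(=O)c2ccc3c(c2)C(C)(C)CCC3(C)C)ccc1/C=C/C(=O)O`: 66%

Compound 1 stands highest of the three. Compound 3 is nearest to it, with a step of a number 12 percentage points lower from compound 1 to compound 3 (beyond the scatter). Compound 2 lies furthest away: in this assay compound 1 gives 78%, whereas compound 2 gives 0%.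

Compound 4 `C/C(=C\c1ccc(C(=O)c2ccc3c(c2)C(C)(C)CCC3(C)C)cc1)C(=O)O` is the next member. Its change from compound 1 is 2-carboxyprop-1-en-1-yl in place of 2-carboxyethenyl on an aromatic carbon.

Among the compounds with values here, no measured step covers this kind of change. Within the data shown here, the one step that is known, a number 12 percentage points lower from compound 1 to compound 3 (beyond the scatter), concerns a methyl on an aromatic carbon and is modest in size; the change to compound 4 also adds one carbon, on the 2-carboxyprop-1-en-1-yl chain. On that single precedent a small loss in this assay is taken as the likelier outcome, though a result within the scatter cannot be ruled out.

For compound 4 the expected value in this assay is 68%, with a range from 45% to 88%. This estimate means an expected step of a number 10 percentage points lower from compound 1 to compound 4 (within the scatter).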

Compound 4, largest response reached (reported as maximum), in percent of the reference or control that the assay uses: 70%
Estimate against measurement, compound 4: 2 percentage points below; measured number inside the range.
By their numbers in this assay, from the lowest: compound 2; then compounds 3, 4 and 1 (each within the scatter of the next, the first and the last beyond it).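

In this assay, 2-carboxyprop-1-en-1-yl in place of 2-carboxyethenyl, on the aromatic carbon para to a large group, gives a number 8 percentage points lower from compound 1 to compound 4 (within the scatter) and so leaves the maximal response indistinguishable from that of compound 1. Within the data shown here, the only earlier single change, a methyl on an aromatic carbon, gave a number 12 percentage points lower from compound 1 to compound 3 (beyond the scatter) and lies beyond the scatter, so the series now shows that an added carbon on the chain itself can be accommodated at this position. The data shown offer no explanation for this outcome.

From the compounds shown here alone, it remains open whether a longer chain, such as an ethyl in place of the added methyl, would keep this response. Also open, going by these compounds, is whether a primary amide or a tetrazole in place of the carboxylic acid on this chain would retain activation.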